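A few compounds are considered here, and "the series" means these few. Any claim that something is new, unique, unknown or untested is made for them only; others in the source may bear on it.

Within the data shown here, in this set, compound 2 `Cc1cn(-c2cc(C(=O)Nc3ccc(-n4ccc5c(NC(=O)c6ccccc6)ncnc54)cc3)cc(C(F)(F)F)c2)cn1` holds the lower of the two numbers measured so far. In a functional assay on A375P cells (Homo sapiens) for antiproliferative activity, read by MTT assay, with a stated time of 24 h (a lower number here means a stronger inhibitor, a higher number a weaker inhibitor), compound 2 gives 800 nM, while compound 1 `O=C(Nc1ccc(-n2ccc3c(NC(=O)c4ccccc4)ncnc32)cc1)c1ccc(Cl)c(Cl)c1` gives 2000 nM, a gap beyond the usual scatter, so compound 2 stands as the stronger of the two.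

Compound 3 `O=C(Nc1ccc(-n2ccc3c(NC(=O)c4ccccc4)ncnc32)cc1)c1cc(C(F)(F)F)cc(C(F)(F)F)c1` has not been measured. It differs from compound 2 in one place: trifluoromethyl in place of 4-methyl-1H-imidazol-1-yl on an aromatic carbon. Among the measured compounds shown here, compound 1 shows that a tail bearing two small halogen-type substituents still gives a measurable number, yet no measured pair shows the effect of exchanging the imidazole for a trifluoromethyl group directly, so the size of the step remains uncertain.

Compound 3 is expected to give a somewhat higher number, a step toward weaker inhibition that may reach just beyond the scatter, estimated as a 1.9-fold higher number from compound 2 to compound 3 (0.27 log units; within the scatter). The value for compound 3 is estimated at 1500 nM, with a range from 500 nM to 5000 nM.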

Compound 3, half-maximal inhibitory concentration: 2000 nM
The estimate for compound 3 lay 1.3-fold (0.12 log units) below the measured number, within the range that was stated.
By their numbers in this assay, from the lowest: compound 2; then compounds 1 and 3 (each within the scatter of the next).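

Among these compounds, the swap of 4-methyl-1H-imidazol-1-yl for trifluoromethyl gives the first direct reading at this aromatic carbon: in this assay the change is a 2.5-fold higher number from compound 2 to compound 3 (0.40 log units; beyond the scatter). The step is modest but beyond the scatter, so the group on this carbon does affect the number, and the compound carrying the 4-methyl-1H-imidazol-1-yl group holds the lower value of this pair. Nothing measured here gives a reason for the step.

What remains open is whether the ring itself or its methyl group accounts for the difference, since an unsubstituted imidazole on this carbon is not among the compounds shown. Also unknown is how an open-chain amine such as dimethylamino, or a carboxylic acid, would behave at the same place.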